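A few compounds are considered here, and "the series" means these few. Any claim that something is new, unique, unknown or untested is made for them only; others in the source may bear on it.

For the measured compounds named here, compound 1 `O=C(C1CCC1)N1CCc2nc(C#Cc3ccccc3)sc2C1` is the only member of this small set that returns a number in an assay on HEK293 cells for negative allosteric modulation of metabotropic glutamate receptor 5 (Homo sapiens), read by FLIPR, with a stated time of 1 h (on this read-out higher numbers stand for weaker inhibition and lower numbers for stronger inhibition), where compound 1 gives 370 nM. Compound 2 `O=S(=O)(C1CCCCC1)N1Cc2nc(C#Cc3ccccc3)sc2C1` reaches only the limit of this assay, > 10000 nM. Compound 3 `O=S(=O)(N1CCCCC1)N1Cc2nc(C#Cc3ccccc3)sc2C1` likewise stops at the limit, > 10000 nM. Going by the values given here, the one measured step, a step that the two limits leave unreadable from compound 2 to compound 3, is therefore unreadable in size and direction, as both of its ends sit at the limit of > 10000 nM in this assay, at which 2 of the 3 values shown sit, and no step connects compound 1 with either sulfonyl compound.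

Compound 4 `O=C(N1CCCC1)N1CCc2nc(C#Cc3ccccc3)sc2C1` has not yet been measured. It differs from compound 1 in one place: pyrrolidin-1-yl in place of cyclobutyl on a carbonyl carbon. Among the compounds with values here, the change most like it among the measured compounds is the one from compound 2 to compound 3, which exchanges a carbocycle for a nitrogen-linked saturated ring on a sulfonyl sulfur, but that step gives no usable size. There is thus no measured evidence pointing to a shift of either sign, and the expectation for this assay is a step within the usual scatter, which is what a 1.4-fold higher number from compound 1 to compound 4 (0.13 log units; within the scatter) is meant to express. On that basis compound 4 is estimated to give 500 nM in this assay, with a range from 150 nM to 1800 nM.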

Compound 4, half-maximal inhibitory concentration: > 10000 nM
Compound 4 gave a limit, no number; the forecaster's own chance of this, stated with the estimate: 8%; at least 20-fold (1.30 log units) between middle value and limit.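

For the compounds shown here, the exchange on this carbonyl carbon is far from neutral in this assay: the step reads an at least 27-fold higher number from compound 1 to compound 4 (1.43 log units; beyond the scatter), and it is the first step in the set with a readable size, showing that this position responds strongly to a single change of ring. Compound 4 itself gives only a limit, > 10000 nM, and not a number, so the step fixes how large the change must be at minimum and not its full size. With a carbonyl carbon kept in place, the change from cyclobutyl to pyrrolidin-1-yl is enough to reach the same limit that until now had been seen only among the sulfonyl compounds: the limit of > 10000 nM in this assay, at which 3 of the 4 values shown sit.

The change alters two things at once, since the entering group brings a nitrogen on the carbonyl carbon and also a five-membered ring in place of a four-membered one, and the compounds shown do not separate these two. From the compounds shown here alone, whether cyclopentyl, which keeps carbon on the carbonyl carbon with the larger ring, or azetidin-1-yl, which brings the nitrogen with a four-membered ring, would return a number in this assay stays open.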